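Opening the question of a basic chain on the core

A few compounds are considered here, and "the series" means these few. Any claim that something is new, unique, unknown or untested is made for them only; others in the source may bear on it.

The compounds here share one core and differ only in what sits on an oxygen on an aromatic ring. Compound 1 is `CC(=O)Oc1ccc([C@@H]2Oc3ccccc3[C@H](c3ccc(O)cc3)[C@H]2c2ccccc2)cc1`. In an ADME assay on HEK293 cells (Homo sapiens) for antiproliferative activity, read by MTT assay, with a stated time of 48 h (on this read-out lower numbers stand for stronger inhibition and higher numbers for weaker inhibition), compound 1 gives > 100000 nM, which is a limit of the assay rather than a number. Compound 2 is `Oc1ccc([C@H]2c3ccccc3O[C@@H](c3ccc(O)cc3)[C@@H]2c2ccccc2)cc1`. In this assay compound 2 gives > 500000 nM, again a limit rather than a number. The step that the two limits leave unreadable from compound 1 to compound 2 therefore cannot be read in size or direction, as the limit of > 100000 nM in this assay, at which 1 of the 2 values shown sits, and the limit of > 500000 nM in this assay, at which 1 of the 2 values shown sits, together show. Compound 3 is `CC(=O)Oc1ccc([C@@H]2Oc3ccccc3[C@H](c3ccc(OCCCN(C)C)cc3)[C@H]2c2ccccc2)cc1`, and it differs from compound 1 by 3-(dimethylamino)propyl in place of hydrogen on an oxygen on an aromatic ring. No measured step in this set touches that change, so nothing shown points to a movement beyond the scatter in either direction. The expected step of a number no higher from compound 1 to compound 3 (the limit leaves the size open) is accordingly taken as small, with a wide margin on either side. For compound 3 the estimate in this assay is 100000 nM, with a range from 15000 nM to 500000 nM.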

Compound 3, half-maximal inhibitory concentration: 14000 nM
For compound 3 the middle estimate is 7.1-fold (0.85 log units) above the measured one; the measured number lies below the stated range.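

Going by these compounds alone, until now the shared core had given only limits, and the one step among those compounds cannot be read. Placing 3-(dimethylamino)propyl on an oxygen on an aromatic ring gives the first readable result in this assay: an at least 7.1-fold lower number from compound 1 to compound 3 (0.85 log units; beyond the scatter), so a change at this position can move the number beyond the scatter. The full size of that step stays open because compound 1 stands at a limit and not at a number: the limit of > 100000 nM in this assay, at which 1 of the 3 values shown sits.

The compounds shown do not separate the part played by the nitrogen at the end of the chain from that of the chain itself, a question that a plain propyl group or a propyl chain ending in a carboxylic acid would address. Also open, going by these compounds, is how a longer or shorter chain would read, or a ring amine such as piperidine at the chain end, and whether the same chain would move the number with hydrogen in place of acetyl on the other oxygen.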